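Ether chain growth in a small bicyclic amine series

The source may hold more compounds than are shown below. What is called first, only, known or untested is meant among the compounds shown, and "the series" means these compounds.

Measured so far:
compound 1 `CO[C@H]1CC=C2CCN(C)[C@H]2C1` with 100000 nM
compound 2 `CCO[C@H]1CC=C2CCN(C)[C@H]2C1` with > 300000 nM

In an assay on HEK293 cells for displacement of a labelled ligand from Neuronal acetylcholine receptor; alpha4/beta4 (Rattus norvegicus), with a stated time of 4 h (on this read-out lower numbers stand for stronger inhibition and higher numbers for weaker inhibition), compound 1 gives 100000 nM. Compound 2 carries an ethyl ether where compound 1 carries a methyl ether; in this assay compound 2 reaches only the limit of > 300000 nM, so no number is known for it and it stands at the limit of > 300000 nM in this assay, at which 1 of the 2 values shown sits. Going by the values given here, the one measured step, an at least 3.0-fold higher number from compound 1 to compound 2 (0.47 log units; beyond the scatter), runs in the weakening direction.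

Compound 3 `CN1CCC2=CC[C@H](OCc3ccccc3)C[C@@H]21` is not yet measured. It differs from compound 2 by phenyl in place of methyl on a saturated chain carbon bound to an oxygen on a saturated carbon. Among the compounds with values here, only the step from compound 1 to compound 2 bears on this change, and it adds carbon at the same place; with compound 2 already at the limit, a further enlargement of the ether is expected to give no measurable gain, and the estimate is a number no higher from compound 2 to compound 3 (the limit leaves the size open). Compound 3 is therefore expected at 300000 nM, within 50000 nM to 1000000 nM, with a considerable chance that this assay again reports only a limit.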

Compound 3, inhibition constant: 300000 nM
Estimate against measurement, compound 3: no gap at the digits printed, and the stated range covers the measured number.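

In this assay, the step from the methyl ether to the phenyl-bearing ether is a 3.0-fold higher number from compound 1 to compound 3 (0.48 log units; beyond the scatter), so an ether larger than the methyl ether now has a measured size and not only a limit. At this place, the phenyl ring does not bring the number back to that of compound 1, and the direction seen with the ethyl ether holds for this larger group. From the ethyl ether, the step is a number no higher from compound 2 to compound 3 (the limit leaves the size open), and its size cannot be read. Compound 2 has only a limit: the limit of > 300000 nM in this assay, at which 1 of the 3 values shown sits.

Open, going by these compounds, is how a free hydroxyl group at this place would compare with the methyl ether of compound 1. Also open, on these data alone, is whether an amine or a carboxylic acid on a longer chain would lower the number in this assay.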